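Cyclopropylcarbonyl in place of the unsaturated amide of compound 1

This account rests on a few compounds, and the source may have more. Where it says the series, first, only, none or still open, it means among the compounds named here.

Measured compounds:
compound 1 `COc1ccc(CN(C(=O)C=C(C)C)c2cc(OC)c(OC)c(OC)c2)cc1O` gives 290 nM
compound 2 `C/C=C/C(=O)N(Cc1ccc(OC)cc1)c1cc(OC)c(OC)c(OC)c1` gives 500 nM
compound 3 `COc1ccc(CNc2cc(OC)c(OC)c(OC)c2)cc1` gives 18400 nM

These three compounds were tested in a functional assay on HCT-116 cells (Homo sapiens) for inhibition, read by MTT assay, with a stated time of 48 h; on this read-out higher numbers stand for weaker inhibition and lower numbers for stronger inhibition. Compound 1 has the lowest number of the three; compound 2 lies within the scatter of it, so no order between compound 1 and compound 2 can be read, while compound 3 stands far higher. Among the compounds with values here, the one single-point step among the measured compounds, a 37-fold higher number from compound 2 to compound 3 (1.57 log units; beyond the scatter), shows that removing the acyl group from the amide-type nitrogen altogether costs a great deal of potency.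

Compound 4 `COc1ccc(CN(C(=O)C2CC2)c2cc(OC)c(OC)c(OC)c2)cc1O` keeps the acyl group but alters it: cyclopropyl in place of 2-methylprop-1-en-1-yl on a carbonyl carbon. Within the data shown here, no measured pair shows this exact change, so the expectation rests on the step from compound 2 to compound 3 only indirectly: it shows that an acyl group on that nitrogen is what carries the potency, and compound 4 retains one. The cyclopropyl group replaces the 2-methylprop-1-en-1-yl group with a saturated ring of similar size, so a modest step is expected, most likely towards a somewhat higher number, expressed as a 1.7-fold higher number from compound 1 to compound 4 (0.24 log units; within the scatter). Compound 4 is therefore estimated at 500 nM, within a range from 150 nM to 2000 nM.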

Compound 4, half-maximal inhibitory concentration: 49 nM
Compound 4: the middle estimate sits 10-fold (1.01 log units) above what was measured; measured number below the stated range.
By their numbers in this assay, from the lowest: compound 4; then compounds 1 and 2 (each within the scatter of the next); then compound 3.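

Cyclopropyl in place of 2-methylprop-1-en-1-yl on a carbonyl carbon whose other neighbour is the amide-type nitrogen gives a 5.9-fold lower number from compound 1 to compound 4 (0.77 log units; beyond the scatter) in this assay, a step beyond the scatter. The earlier step showed only that losing the whole acyl group from this nitrogen raises the number sharply, whereas this result shows that the group attached to the carbonyl also matters once the acyl group is present, so the carbonyl alone does not set the number at this position. The change removes a double bond outside the aromatic rings and one carbon and brings in a three-membered ring, but no measurement shown here gives a reason for the step.

Within the data shown here, the two compounds cannot separate the effect of the ring from that of losing the double bond, as these changes arrive together in the single step from compound 1 to compound 4. From the compounds shown here alone, it remains open whether an isopropyl group on the same carbonyl, with no ring and no double bond, or a cyclobutyl group, with a larger ring, would match the number of compound 4.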